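The compounds below may be only part of what the source reports. "The series", "measured", "known", "first", "only" and "open" are said of these compounds alone.

Measured compounds in a functional assay on CHO cells for agonist activity at adenosine receptor A1 (Homo sapiens), read by ERK phosphorylation, tested at 10 uM; a higher number here means a stronger effect of the compound at the concentration tested, a lower number a weaker effect:
compound 1 `NNC(=O)c1c(N)sc2c1CCCCCC2`: 48%
compound 2 `Nc1sc2c(c1C(=O)NCc1ccccc1)CCCCCC2`: 50%

In this assay compound 1 gives 48%, and compound 2 gives 50%. Within the data shown here, the only measured step, a number 2 percentage points higher from compound 1 to compound 2 (within the scatter), is within the scatter, so neither of these two numbers stands apart from the other; compound 1 simply has the smaller figure of a pair that cannot be told apart.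

Compound 3 `Cc1ccc(C(=O)c2c(N)sc3c2CCCCCC3)cc1` is not yet measured. Against compound 1 it shows (4-methylphenyl in place of aminoamino on a carbonyl carbon). The measured step of a number 2 percentage points higher from compound 1 to compound 2 (within the scatter) concerns a substituent on the amide-type nitrogen, a nitrogen that leaves altogether in the change to compound 3, and that step stayed within the scatter. Among the measured compounds shown here, no measured step replaces the whole group on the carbonyl carbon, so no direction can be argued from the data. The expected step of a number 3 percentage points lower from compound 1 to compound 3 (within the scatter) is therefore one of no size beyond the scatter, held with wide bounds. Compound 3 is estimated at 45%, range 15% to 75%.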

Compound 3, a percentage reported as activity, at one concentration (the size of the read-out at that concentration, not a potency): 75%
Compound 3: middle estimate off by 30 percentage points, on the low side, within the range that was stated.
By their numbers in this assay, from the lowest: compounds 1 and 2 (each within the scatter of the next); then compound 3.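

In this assay, among these compounds, the group on the carbonyl carbon does move the read-out: 4-methylphenyl in place of aminoamino gives a number 27 percentage points higher from compound 1 to compound 3 (beyond the scatter) and is the first step beyond the scatter, whereas the earlier change on the amide-type nitrogen did not separate its two compounds. Compound 3 also shows that neither the amide-type nitrogen nor the hydrogen-bond donors of aminoamino are needed for a read-out of this size at the concentration tested. No measurement bears on the origin of this rise.

The compounds shown do not separate the aromatic ring from its methyl, a question that plain phenyl on the same carbonyl carbon would address. From the compounds shown here alone, it also remains open whether a non-aromatic group such as cyclohexyl or a short alkyl chain at this place would give a similar number.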